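This account rests on a few compounds, and the source may have more. Where it says the series, first, only, none or still open, it means among the compounds named here.

Compound 1 `CCc1nc2ccc(Cl)cn2c1C(=O)NCc1ccc2c(c1)CCN(Cc1cc(F)cc(F)c1)C2`: 14 ug/mL
Compound 2 `CCc1nc2ccc(Cl)cn2c1C(=O)NCc1ccc2c(c1)CCN(Cc1ccc(C(F)(F)F)cn1)C2`: > 64 ug/mL

In an ADME assay on Vero cells (Chlorocebus sabaeus) for cytotoxicity, read by MTT assay, with a stated time of 72 h (a lower number here means that less compound is tolerated, a higher number that more compound is tolerated), compound 2 gives > 64 ug/mL, which is a limit of the assay and not a number. Compound 3 `CCc1nc2ccc(Cl)cn2c1C(=O)NCc1ccc2c(c1)CCN(Cc1ccc(Br)cc1)C2` is not yet measured. It carries 4-bromophenyl in place of 5-(trifluoromethyl)pyridin-2-yl on a saturated chain carbon bound to an amine nitrogen in a ring. For the measured compounds named here, the one measured step at this place, an at least 4.5-fold higher number from compound 1 to compound 2 (0.66 log units; beyond the scatter), lies beyond the scatter and brought in the group that now leaves, replacing 3,5-difluorophenyl. One step is thin evidence, but a change of similar size toward a lower number is expected here. The estimated step is an at least 4.0-fold lower number from compound 2 to compound 3 (0.60 log units; beyond the scatter). In this assay, compound 3 is expected at 16 ug/mL, with an estimated range of 6 ug/mL to 48 ug/mL.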

Compound 3, half-maximal cytotoxic concentration: 30 ug/mL
Compound 3: middle estimate off by 1.9-fold (0.27 log units), on the low side; the range from low to high includes it.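

On the saturated chain carbon, 4-bromophenyl separates from both earlier groups in this assay: an at least 2.1-fold lower number from compound 2 to compound 3 (0.32 log units; beyond the scatter), and a 2.1-fold higher number from compound 1 to compound 3 (0.33 log units; beyond the scatter). Compound 3 therefore falls in the middle of the three, so the change of group gives a graded series, not just two levels. Compound 2 stands at a limit of the assay, not a number: the limit of > 64 ug/mL in this assay, at which 1 of the 3 values shown sits.

The compounds shown do not separate the effect of the ring nitrogen in compound 2 from that of its trifluoromethyl group. From the compounds shown here alone, how an amine or a carboxylic acid on this ring would fare also remains open.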